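The compounds below may be only part of what the source reports. "The series", "measured", "known", "first", "only" and "open" are said of these compounds alone.

Compound 1 `COc1cc(N2C(N)=C(C#N)C(c3ccc([N+](=O)[O-])cc3)C3=C2CC(C)(C)CC3=O)cc(OC)c1OC` is a member of the series that in a functional assay on Ehrlich cells (Mus musculus) for cytotoxicity, tested at 50 ug/mL (a lower number here means a weaker effect, a higher number a stronger effect of the compound at the concentration tested), gives 70%. Among the three measured compounds this is the second highest number. Compound 2 `COc1cc(N2C(N)=C(C#N)C(c3ccc(Cl)cc3Cl)C3=C2CC(C)(C)CC3=O)cc(OC)c1OC` gives 95%, and the step of a number 25 percentage points higher from compound 1 to compound 2 (beyond the scatter) lies beyond the scatter. Compound 3 `COc1cc(N2C(N)=C(C#N)C(c3ccc(C)cc3)C3=C2CC(C)(C)CC3=O)cc(OC)c1OC` gives 60%; the step of a number 10 percentage points lower from compound 1 to compound 3 (within the scatter) stays within the scatter, so compound 1 and compound 3 cannot be told apart on this read-out. The step of a number 35 percentage points lower from compound 2 to compound 3 (beyond the scatter) is the widest gap seen so far.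

Compound 4 `COc1cc(N2C(N)=C(C#N)C(c3ccccc3Cl)C3=C2CC(C)(C)CC3=O)cc(OC)c1OC` has not yet been measured. Its change from compound 1 is 2-chlorophenyl in place of 4-nitrophenyl on a saturated ring carbon. Among the compounds with values here, the only measured step that bears on it is the exchange of the same 4-nitrophenyl for a chlorinated phenyl, a number 25 percentage points higher from compound 1 to compound 2 (beyond the scatter), a modest gain beyond the scatter. Compound 4 carries 2-chlorophenyl rather than 2,4-dichlorophenyl, so only part of that gain is expected to carry over, and nothing measured rules out a step within the scatter. For compound 4 the step of a number 10 percentage points higher from compound 1 to compound 4 (within the scatter) is expected, a rise in the direction shown by compound 2. The estimate for compound 4 is 80%, expected to fall between 65% and 95%.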

Compound 4, a percentage reported as activity, at one concentration (the size of the read-out at that concentration, not a potency): 20%
Compound 4: the middle estimate sits 60 percentage points above what was measured, and the stated range ends above it.
By their numbers in this assay, from the lowest: compound 4; then compounds 3 and 1 (each within the scatter of the next); then compound 2.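

In this assay, within the data shown here, this saturated ring carbon proves much more sensitive to the choice of aryl group than the earlier compounds showed: 2-chlorophenyl in place of 4-nitrophenyl gives a number 50 percentage points lower from compound 1 to compound 4 (beyond the scatter) and 2-chlorophenyl in place of 4-methylphenyl gives a number 40 percentage points lower from compound 3 to compound 4 (beyond the scatter) so the chlorinated phenyl does not carry the gain seen with 2,4-dichlorophenyl. Among these compounds, the single change of hydrogen in place of chloro on an aromatic carbon gives a number 75 percentage points lower from compound 2 to compound 4 (beyond the scatter) and this is the widest gap in the set, leaving the two chlorinated compounds at opposite ends, with compound 2 highest and compound 4 lowest, so the presence of a chloro alone does not set the level of the read-out. No measured evidence accompanies these compounds to account for the drop.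

The compounds shown leave open where an unsubstituted phenyl would fall, and so whether the 2-chlorophenyl group lowers the number or the second chloro of 2,4-dichlorophenyl raises it. Also open, as far as these compounds go, is how a fluorophenyl, methoxyphenyl or aminophenyl group would read at this carbon with the rest of the core kept unchanged.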